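A few compounds are considered here, and "the series" means these few. Any claim that something is new, unique, unknown or untested is made for them only; others in the source may bear on it.

Measured in a physicochemical assay for lipophilicity, at pH 7.4; on this read-out lower numbers stand for lower lipophilicity and higher numbers for higher lipophilicity:
compound 1 `CNC(=O)c1cc(C(=O)NC2CC2)cc2c1OC[C@H]2c1cccc2[nH]ccc12` gives 3.5
compound 2 `CNC(=O)c1cc(C(=O)N[C@H]2[C@@H]3COC[C@@H]32)cc2c1OC[C@H]2c1ccc(F)cc1` gives 3.6

Compound 2 stands at 3.6 within the usual scatter of compound 1 at 3.5 and the two numbers do not separate. The two compounds differ in more than one place, so no measured single change is available as a guide. In compound 3 `CNC(=O)c1cc(C(=O)NC2CC2)cc2c1OC[C@H]2c1ccc(F)cc1` the change from compound 2 is a group of 3 heavy atoms (3 carbon; one three-membered non-aromatic ring of carbon only) in place of a group of 6 heavy atoms (5 carbon, 1 oxygen; one three-membered non-aromatic ring of carbon only, one five-membered non-aromatic ring with 1 hetero atom), on an amide-type nitrogen and it sits on an amide-type nitrogen. Compound 1 also carries cyclopropyl on that nitrogen, but its remainder differs, so its 3.5 is only a loose anchor. A small upward move in this assay is expected, and it is not expected to go beyond the scatter. The estimated step of a number 0.20 log units higher from compound 2 to compound 3 (within the scatter) rests on little direct evidence. For compound 3 the estimated value is 3.8 with an expected range from 3.4 to 4.2 as the upper end.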

Compound 3, distribution coefficient: 3.8
Estimate against measurement, compound 3: no gap at the digits printed; measured number inside the range.
By their numbers in this assay, from the lowest: compounds 1, 2 and 3 (each within the scatter of the next).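

In this assay, cyclopropyl in place of the group of 6 heavy atoms on the amide-type nitrogen gives a number 0.20 log units higher from compound 2 to compound 3 (within the scatter), so this first single change read at that position does not separate the two compounds. On a saturated ring carbon, 4-fluorophenyl in place of 1H-indol-4-yl gives a number 0.30 log units higher from compound 1 to compound 3 (within the scatter), so this second position also shows no separation, and the two steps together leave all three compounds unresolved on this read-out. No measurement on hand bears on a reason for either step.

Going by these compounds, whether an amine or a carboxylic acid on the amide-type nitrogen would give a step beyond the scatter stays open. The same question stands for a longer chain on that nitrogen, and for any group other than these two aryl groups on the saturated ring carbon.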